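This account rests on a few compounds, and the source may have more. Where it says the series, first, only, none or still open, it means among the compounds named here.

Going by the values given here, in a functional assay on HL-60 cells (Homo sapiens) for cytotoxicity, read by ELISA, with a stated time of 2 days (on this read-out lower numbers stand for stronger inhibition and higher numbers for weaker inhibition), two compounds have numbers so far. Among the compounds with values here, compound 1 (`Oc1cccc(-c2cc(-c3ccccc3)cc(-c3cccs3)n2)c1`) gives 14100 nM and compound 2 (`Oc1cccc(-c2cc(-c3ccccc3)nc(-c3ccsc3)c2)c1`) gives 12000 nM so compound 2 stands within the scatter of the only other value. Compound 3 (`Oc1cccc(-c2cc(-c3ccccc3)nc(-c3cccnc3)c2)c1`) carries pyridin-3-yl in place of thiophen-3-yl on an aromatic carbon. Within the data shown here, no measured pair shows this exchange, so no step beyond the scatter is expected in this assay and no firm direction can be given. The estimated step of a 1.2-fold higher number from compound 2 to compound 3 (0.07 log units; within the scatter) stays within that scatter. Compound 3 is estimated at 14000 nM with an expected range from 6000 nM to 35000 nM in this estimate.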

Compound 3, half-maximal inhibitory concentration: 12600 nM
Estimate against measurement, compound 3: 1.1-fold (0.05 log units) above; the range from low to high includes it.
By their numbers in this assay, from the lowest: compounds 2, 3 and 1 (each within the scatter of the next).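

In this assay, going by these compounds alone, the exchange of thiophen-3-yl for pyridin-3-yl gives a 1.1-fold higher number from compound 2 to compound 3 (0.02 log units; within the scatter) and is the first single exchange that can be read at this position. On this aromatic carbon, a six-membered aromatic ring with one hetero atom thus stands level with a five-membered one. No measured property bears on this result. Going by these compounds, what the same carbon would give with an amine, a carboxylic acid or pyridin-4-yl stays open. So does whether any group at this position can move the number beyond the scatter.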